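Dropping the propyl from compound 3: series notes

A few compounds are considered here, and "the series" means these few. Any claim that something is new, unique, unknown or untested is made for them only; others in the source may bear on it.

Measured in a physicochemical assay for lipophilicity, measured as octanol-water partition, at pH 7.4 (a higher number here means a more lipophilic compound, a lower number a more polar compound), so far:
- compound 1 `Cc1nc(N)c2c(n1)N(Cc1ccccc1)C(=O)C2`: 2
- compound 2 `COCCNc1nc(N)c2c(O)nn(Cc3ccccc3)c2n1`: "not determined" (no result reported)
- compound 3 `CCCc1cc2c([nH]c(=O)n2Cc2ccccc2)c(N)n1`: 3.1

Compound 3 holds the higher of the two numbers available in this assay; its nearest neighbour is compound 1, which lies lower by a margin beyond the usual scatter. Compound 2 gives no number, so nothing can be read from it. No pair of these compounds differs in a single place, and no step between measured compounds is available to lean on.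

The next entry is compound 4 `Nc1nccc2c1[nH]c(=O)n2Cc1ccccc1`, which is still to be measured in this assay. Against compound 3 it differs in one place: hydrogen in place of propyl on an aromatic carbon. The change takes three heavy atoms out of the molecule and leaves a hydrogen in their stead.

For the measured compounds named here, with no measured step of this kind, the expectation rests on the size of the group that leaves. A loss of three carbons without any change in donors, acceptors or charge is expected to move the number downward, by a step beyond the scatter, and the estimated step of a number 1.30 log units lower from compound 3 to compound 4 (beyond the scatter) reflects that. Compound 4 is therefore expected to give about 1.8 in this assay, in a range from 1.2 to 2.4.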

Compound 4, distribution coefficient: 1.9
Compound 4: the middle estimate sits 0.10 log units below what was measured; measured number inside the range.
By their numbers in this assay, from the lowest: compounds 4 and 1 (each within the scatter of the next); then compound 3.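

Hydrogen in place of propyl on an aromatic carbon gives a number 1.20 log units lower from compound 3 to compound 4 (beyond the scatter) in this assay, the first change in the series that can be read at a single place. For the compounds shown here, the earlier compounds offered no such pair, so this aromatic carbon, next to the ring nitrogen, is now the one position where a change has a measured size. The group that leaves consists of carbon only, with 0 hydrogen-bond donors, 0 hydrogen-bond acceptors and no net charge, and nothing at hand shows the origin of a step of this size.

Going by these compounds, whether a methyl, an ethyl or a longer chain on this aromatic carbon would fall between compound 4 and compound 3 stays open, as does where an amine or a carboxylic acid at the same place would stand. A single pair also cannot tell whether the same exchange would give a step of similar size on a different core, or whether the size of the step depends on the rest of the molecule.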